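The source may report more compounds than this note shows. Statements on the series, on what has been measured and on what is new or still open speak of the compounds shown alone.

Compound 1 `CCOC(=O)c1ccc(NC(=O)N2CC2C#N)cc1` gives 2900 nM in a functional assay on A549 cells (Homo sapiens) for inhibition; a lower number here means a stronger inhibitor, a higher number a weaker inhibitor.
Compound 2 `N#CC1CN1C(=O)Nc1ccc(Cl)cc1Cl` gives 2500 nM in this assay.
Compound 3 `N#CC1CN1C(=O)Nc1cccc2ccccc12` gives 2500 nM in this assay.

All three numbers lie within the usual scatter of one another, so compound 1 cannot be told apart from compound 2 or compound 3 in this assay; the three share a common core and differ only in the aromatic part attached to the urea.

Compound 4 `N#CC1CN1C(=O)Nc1ccc(S(N)(=O)=O)cc1` is the next compound, made from compound 1 by one change: sulfamoyl in place of ethoxycarbonyl on an aromatic carbon. Within the data shown here, no measured pair shows what such a swap does here, so nothing in the data sets its size. A modest effect is expected, most likely none beyond the scatter, in either direction. Compound 4 is therefore expected to give about 3000 nM in this assay, within a range of 1000 nM to 9000 nM, which corresponds to a step of a 1.0-fold higher number from compound 1 to compound 4 (0.01 log units; within the scatter).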

Compound 4, half-maximal inhibitory concentration: > 38000 nM
Compound 4 ended at the assay's limit; the forecaster's own chance of this, stated with the estimate: 10%; middle value at least 12-fold (1.10 log units) from the limit.
By their numbers in this assay, from the lowest: compounds 2, 3 and 1 (each within the scatter of the next). At a limit, above all of these: compound 4.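

The earlier compounds shown here gave no sign that the aromatic part mattered: compound 1, compound 2 and compound 3 all lie within the scatter of one another in this assay. Compound 4 reads > 38000 nM, which is a limit of the assay and not a number. Sulfamoyl in place of ethoxycarbonyl gives an at least 13-fold higher number from compound 1 to compound 4 (1.11 log units; beyond the scatter), so the group at this place on the ring can matter a great deal.

Which feature of sulfamoyl counts remains open, as this one swap replaces the whole group. As far as these compounds go, how a carboxylic acid or an amine would behave at this place is also open.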